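This account rests on a few compounds, and the source may have more. Where it says the series, first, only, none or still open, it means among the compounds named here.

Within the data shown here, in an ADME assay on microsomes from liver (Homo sapiens) for metabolic stability, read by LC-MS, tested at 0.5 uM (a lower number here means that the compound disappears faster, a higher number that the compound lasts longer), compound 3 `Cc1nc(C)c([C@H](OC(C)(C)C)C(=O)O)c(N2CCC(C)(C)CC2)c1-c1ccc(OC2COCC2c2ccc(F)cc2)cc1` gives 0.783 h, the only plain number among the three measured compounds. Compound 1 `Cc1nc(C)c([C@H](OC(C)(C)C)C(=O)O)c(N2CCC(C)(C)CC2)c1-c1ccc(OCCc2ccc(F)c(F)c2)cc1` reaches > 2 h, which is a limit of the assay rather than a number. Compound 2 `Cc1nc(C)c([C@H](OC(C)(C)C)C(=O)O)c(N2CCC(C)(C)CC2)c1-c1ccc(CCCc2ccc(F)cc2)cc1` likewise reaches the limit > 2 h. Compound 4 `Cc1nc(C)c([C@H](OC(C)(C)C)C(=O)O)c(N2CCC(C)(C)CC2)c1-c1ccc(OCCc2ccccn2)cc1` carries 2-(pyridin-2-yl)ethyl in place of 4-(4-fluorophenyl)oxolan-3-yl on an oxygen on an aromatic ring. Of the measured steps, a step that the two limits leave unreadable from compound 1 to compound 2 cannot be read, whereas an at least 2.5-fold lower number from compound 1 to compound 3 (0.40 log units; beyond the scatter) is readable and runs opposite to the change at hand, which again places an ethyl-linked aromatic ring on the oxygen as in compound 1. The number for compound 4 is therefore expected to rise, with a 1.9-fold higher number from compound 3 to compound 4 (0.28 log units; within the scatter). Compound 4 is estimated at 1.5 h, between 0.6 h and 3 h, with a fair chance that only the limit is reported.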

Compound 4, half-life: 0.5 h
For compound 4 the middle estimate is 3.0-fold (0.48 log units) above the measured one, outside the stated range (below it).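

In this assay, the ethyl link on the oxygen does not by itself hold the half-life: with that link kept, exchanging the ring at its end gives an at least 4.0-fold lower number from compound 1 to compound 4 (0.60 log units; beyond the scatter). Replacing the whole group gives a 1.6-fold lower number from compound 3 to compound 4 (0.19 log units; within the scatter), so 2-(pyridin-2-yl)ethyl and 4-(4-fluorophenyl)oxolan-3-yl are not told apart here, while the other comparison gives an at least 4.0-fold lower number from compound 2 to compound 4 (0.60 log units; beyond the scatter). Compound 1 and compound 2 stand at a limit, so the full size of their steps stays unknown: the limit of > 2 h in this assay, at which 2 of the 4 values shown sit.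

Going by these compounds, whether a plain phenyl at the end of the ethyl link would behave like 3,4-difluorophenyl or like pyridin-2-yl remains open. So does the effect of a longer chain carrying pyridin-2-yl on that oxygen.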